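Swapping a Methoxyphenyl for a Difluorophenyl

The source may report more compounds than this note shows. Statements on the series, on what has been measured and on what is new or still open speak of the compounds shown alone.

Three measured compounds share one core and differ only in the ring on the carbonyl carbon. Compound 1 `COc1cc(-c2cc(/C=C/C(=O)c3ccc(N)cc3)[nH]n2)cc(OC)c1OC` gives 10500 nM in a functional assay on IGROV-1 cells (Homo sapiens) for inhibition, read by sulforhodamine B assay, with a stated time of 48 h; on this read-out lower numbers stand for stronger inhibition of growth and higher numbers for weaker inhibition of growth. Compound 2 `COc1ccc(C(=O)/C=C/c2cc(-c3cc(OC)c(OC)c(OC)c3)n[nH]2)cc1OC` gives 3410 nM, and compound 3 `COc1ccc(C(=O)/C=C/c2cc(-c3cc(OC)c(OC)c(OC)c3)n[nH]2)cc1` gives 4810 nM, second highest of the three numbers. The step of a 2.2-fold lower number from compound 1 to compound 3 (0.34 log units; beyond the scatter) was modest, while the step of a 1.4-fold higher number from compound 2 to compound 3 (0.15 log units; within the scatter) stayed within the scatter. Compound 4 `COc1cc(-c2cc(/C=C/C(=O)c3ccc(F)c(F)c3)[nH]n2)cc(OC)c1OC` differs from compound 3 by 3,4-difluorophenyl in place of 4-methoxyphenyl on a carbonyl carbon. Among the measured compounds shown here, no measured step puts fluorine on this ring, so the two changes seen at this position, both modest or smaller, are the only guide. The number for compound 4 is therefore expected to stay near that of compound 3, the estimated step of a 1.0-fold higher number from compound 3 to compound 4 (0.02 log units; within the scatter) being uncertain in direction. Compound 4 is estimated at 5000 nM, within 1500 nM to 16000 nM.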

Compound 4, concentration for total growth inhibition: 87000 nM
Beside the measured number, compound 4's estimate is 17-fold (1.24 log units) below it, and the stated range ends below it.
By their numbers in this assay, from the lowest: compounds 2 and 3 (each within the scatter of the next); then compound 1; then compound 4.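

Among the compounds shown here, the ring on the carbonyl carbon matters far more than the earlier compounds suggested. In this assay, 3,4-difluorophenyl brings a large loss of growth inhibition against the methoxy-bearing rings: an 18-fold higher number from compound 3 to compound 4 (1.26 log units; beyond the scatter), and a 26-fold higher number from compound 2 to compound 4 (1.41 log units; beyond the scatter). The 4-aminophenyl ring, which gave the highest earlier number, also does better, with an 8.3-fold higher number from compound 1 to compound 4 (0.92 log units; beyond the scatter).

As far as these compounds go, whether a single fluorine, a chlorine or a hydroxyl on this ring would behave like methoxy or like the two fluorines stays open. Nothing available explains the loss.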